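This account rests on a few compounds, and the source may have more. Where it says the series, first, only, none or still open, it means among the compounds named here.

In an ADME assay on the whole organism (strain 129/SvEvBrd x C57BL/6) for metabolic stability, with Mus musculus as the target (on this read-out higher numbers stand for a longer-lived compound and lower numbers for a shorter-lived compound), three compounds sharing one core have numbers: compound 1 `CN(C)C(=O)c1nc([C@@H](O)[C@H](O)[C@H](O)CO)c[nH]1` gives 4 h while compound 2 `CC(F)(F)c1nc([C@@H](O)[C@H](O)[C@H](O)CO)c[nH]1` gives 1 h and compound 3 `Cc1nc(-c2nc([C@@H](O)[C@H](O)[C@H](O)CO)c[nH]2)cs1` gives 2.1 h on the same scale. Two steps place compound 3 in this small set: a 1.9-fold lower number from compound 1 to compound 3 (0.28 log units; within the scatter) stays within the scatter, whereas a 2.1-fold higher number from compound 2 to compound 3 (0.32 log units; beyond the scatter) goes modestly beyond it. Compound 4 `OC[C@@H](O)[C@@H](O)[C@H](O)c1c[nH]c(-c2cscn2)n1` differs from compound 3 by a single change hydrogen in place of methyl on an aromatic carbon with hydrogen in place of methyl on an aromatic carbon, turning 2-methyl-1,3-thiazol-4-yl into 1,3-thiazol-4-yl. Among the measured compounds shown here, no measured step removes this methyl alone. The nearest evidence comes from exchanges of the whole group on the core, and even the largest of these, a 4.0-fold lower number from compound 1 to compound 2 (0.60 log units; beyond the scatter) is only modest. A much smaller edit is therefore expected to move the number in this assay by no more than the scatter. The expected step is a 1.1-fold lower number from compound 3 to compound 4 (0.02 log units; within the scatter) and would lie within the scatter. Compound 4 is estimated at 2 h with an expected range from 1 h to 4 h in that measurement.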

Compound 4, half-life: 4.2 h
The estimate for compound 4 lay 2.1-fold (0.32 log units) below the measured number; measured number above the stated range.
By their numbers in this assay, from the lowest: compound 2; then compounds 3, 1 and 4 (each within the scatter of the next).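

Removing the methyl from the 2-methyl-1,3-thiazol-4-yl group is now measured directly in this assay, and it gives a 2.0-fold higher number from compound 3 to compound 4 (0.30 log units; within the scatter) at this position, so this single change stays inside the scatter, though only just. The whole-group exchange for dimethylcarbamoyl likewise gives a 1.1-fold higher number from compound 1 to compound 4 (0.02 log units; within the scatter) and does not separate the two groups, whereas the exchange for 1,1-difluoroethyl gives a 4.2-fold higher number from compound 2 to compound 4 (0.62 log units; beyond the scatter) and is a modest step beyond the scatter. The 1,3-thiazol-4-yl group thus stands apart from 1,1-difluoroethyl more clearly than its methylated form did, but nothing shown explains these numbers.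

Still open, as far as these compounds go, is whether a larger group on that aromatic carbon, such as ethyl, or an amine there, would leave the half-life within the scatter. Also open, from the compounds shown here alone, is whether removing the methyl would behave the same way on another core.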